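A few compounds are considered here, and "the series" means these few. Any claim that something is new, unique, unknown or untested is made for them only; others in the source may bear on it.

Compound 1 `COc1ccc(OC)c(Sc2ccc3nnc(-c4ccccc4)n3n2)c1` sets the reference point of this small set: in an assay on isolated protein for inhibition of Leucine-rich repeat serine/threonine-protein kinase 2 (Homo sapiens), in the presence of a further agent that is not named here (a lower number here means a stronger inhibitor, a higher number a weaker inhibitor), compound 1 gives 173 nM. Compound 2 `COc1ccc(OC)c(Sc2ccc3nnc(-c4ccsn4)n3n2)c1` carries a 1,2-thiazol-3-yl group where compound 1 has a phenyl, and in this assay compound 2 gives 91 nM. For the measured compounds named here, the only measured step, a 1.9-fold lower number from compound 1 to compound 2 (0.28 log units; within the scatter), stays within the scatter. Among the two numbers compound 2 holds the lower one, but the gap to compound 1 is within the scatter, so no ordering of the two can be claimed.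

Compound 3 `COc1ccc(OC)c(Sc2ccc3nnc(-c4ccn(C)n4)n3n2)c1` has not yet been measured in this assay. It differs from compound 2 by 1-methyl-1H-pyrazol-3-yl in place of 1,2-thiazol-3-yl on an aromatic carbon. Going by the values given here, the one step that bears on this change is a 1.9-fold lower number from compound 1 to compound 2 (0.28 log units; within the scatter), an exchange of one aromatic ring for another at the same place, which produced no movement beyond the scatter. Another exchange of a five-membered aromatic ring at that place is therefore expected to give a step of a 1.2-fold higher number from compound 2 to compound 3 (0.08 log units; within the scatter), with no direction beyond the scatter. Compound 3 is accordingly estimated to give 110 nM in this assay, within a range from 45 nM to 270 nM.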

Compound 3, half-maximal inhibitory concentration: 224 nM
Estimate against measurement, compound 3: 2.0-fold (0.31 log units) below; measured number inside the range.
By their numbers in this assay, from the lowest: compounds 2, 1 and 3 (each within the scatter of the next, the first and the last beyond it).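

In this assay this position gives its first step beyond the scatter, a 2.5-fold higher number from compound 2 to compound 3 (0.39 log units; beyond the scatter), a modest one, when 1-methyl-1H-pyrazol-3-yl replaces 1,2-thiazol-3-yl. The two groups are alike in what is counted, each being one five-membered aromatic ring with 2 hetero atoms, 0 hydrogen-bond donors and 2 hydrogen-bond acceptors, so the number can shift between five-membered rings that match on those counts, while the entering group has 6 heavy atoms against 5 and nitrogen and carbon in place of sulfur. The other new step, a 1.3-fold higher number from compound 1 to compound 3 (0.11 log units; within the scatter), stays within the scatter, so phenyl and 1-methyl-1H-pyrazol-3-yl cannot be told apart at this place, and nothing available explains the difference between the two five-membered rings.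

The ring change and the added methyl arrive together in this step, so the compounds shown cannot separate them, and an unsubstituted 1H-pyrazol-3-yl group would bear directly on that. Also open, on these data alone, is how an amine, a carboxylic acid or a longer chain would read at this place.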